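Carbamoyl to Trifluoromethyl: Expected Cytotoxicity of Compound 4

The source may report more compounds than this note shows. Statements on the series, on what has been measured and on what is new or still open speak of the compounds shown alone.

Of the compounds shown here, three built on one shared core have been measured in an ADME assay on HEK293 cells (Homo sapiens) for cytotoxicity, with a stated time of 72 h; on this read-out higher numbers stand for an effect only at larger amounts of compound and lower numbers for an effect already at smaller amounts. Compound 1 `Cc1cc(NC(=O)Nc2ccc([N+](=O)[O-])c(C(F)(F)F)c2)c2ccccc2n1` carries a nitro and a trifluoromethyl group on its outer ring, compound 2 `Cc1cc(NC(=O)Nc2cccc(Cl)c2)c2ccccc2n1` carries a chloro, and compound 3 `Cc1cc(NC(=O)Nc2cccc(C(N)=O)c2)c2ccccc2n1` carries a carbamoyl. In this assay compound 1 gives > 25000 nM, which is a limit of the assay rather than a number. Compound 2 gives 21000 nM. Compound 3 gives > 25000 nM, again a limit of the assay and not a measured number. Among the measured compounds shown here, the one measured step between neighbouring compounds, an at least 1.1-fold higher number from compound 2 to compound 3 (0.07 log units; that floor lies within the scatter), therefore says little on its own: it rests on (the limit of > 25000 nM in this assay, at which 2 of the 3 values shown sit), where compound 3 sits together with compound 1.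

Compound 4 `Cc1cc(NC(=O)Nc2cccc(C(F)(F)F)c2)c2ccccc2n1` has not yet been measured. It differs from compound 3 by trifluoromethyl in place of carbamoyl on an aromatic carbon. For the measured compounds named here, only one measured step bears on this change, and it ends at a limit, so no direction can be read from it. Because the limit of > 25000 nM in this assay, at which 2 of the 3 values shown sit, holds two of the three values shown, the most likely outcome for compound 4 is another value at or near that limit. Compound 4 is expected to give about 25000 nM, within a range from 12000 nM to 60000 nM. This estimate means a step of a number no higher from compound 3 to compound 4 (the limit leaves the size open), which is expected to stay within the usual scatter.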

Compound 4, half-maximal effective concentration: 16000 nM
Estimate against measurement, compound 4: 1.6-fold (0.19 log units) above, and the stated range covers the measured number.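

In this assay compound 4, with trifluoromethyl, which has no hydrogen-bond donor or acceptor, gives 16000 nM as a true number. Compound 3, with carbamoyl, gives > 25000 nM, which is a limit of the assay. The shared core now has two real numbers for groups on this aromatic carbon. Those two numbers cannot be told apart, as a 1.3-fold lower number from compound 2 to compound 4 (0.12 log units; within the scatter) shows, so trifluoromethyl and chloro look the same here. The other two steps, an at least 1.5-fold lower number from compound 3 to compound 4 (0.19 log units; that floor lies within the scatter) and an at least 1.5-fold lower number from compound 1 to compound 4 (0.19 log units; that floor lies within the scatter), give only a floor and leave their full size unknown, and the change from carbamoyl therefore has no firm size yet, with the start of each step resting on this: the limit of > 25000 nM in this assay, at which 2 of the 4 values shown sit.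

As far as these compounds go, whether an amine, a carboxylic acid or a longer chain on this aromatic carbon would move the number beyond the usual scatter stays open. From the compounds shown here alone, it is also open how far compound 1 and compound 3 really lie from compound 4, and whether nitro alone accounts for any of the gap.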